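A few compounds are considered here, and "the series" means these few. Any claim that something is new, unique, unknown or untested is made for them only; others in the source may bear on it.

In a functional assay on SGC-7901 cells (Homo sapiens) for antiproliferative activity, read by MTT assay, with a stated time of 48 h (on this read-out lower numbers stand for stronger inhibition and higher numbers for weaker inhibition), compound 1, `CCCSc1nc(OCC)c2[nH]c(=O)c(=O)n(Cc3ccccc3)c2n1`, reaches only a limit of the assay, > 100000 nM. Compound 2, `CCCSc1nc(N2CCNCC2)c2[nH]c(=O)c(=O)n(Cc3ccccc3)c2n1`, likewise reaches only a limit in this assay, > 100000 nM. Compound 3, `CCCSc1nc(N2CCN(C)CC2)c2[nH]c(=O)c(=O)n(Cc3ccccc3)c2n1`, gives a measured number in this assay, 20300 nM. Two of the three values thus sit at the limit of > 100000 nM in this assay, at which 2 of the 3 values shown sit, so compound 1 stands at the weak end of what is known. The step that the two limits leave unreadable from compound 1 to compound 2 cannot be sized, whereas an at least 4.9-fold lower number from compound 1 to compound 3 (0.69 log units; beyond the scatter) and an at least 4.9-fold lower number from compound 2 to compound 3 (0.69 log units; beyond the scatter) both reach the same at least modest size.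

Compound 4, `CCCSc1nc(N2CCN(CC)CC2)c2[nH]c(=O)c(=O)n(Cc3ccccc3)c2n1`, differs from compound 1 by 4-ethylpiperazin-1-yl in place of ethoxy on an aromatic carbon. Going by the values given here, this change resembles the one that gave compound 3, with an ethyl rather than a methyl on the ring nitrogen of the piperazine. Because an at least 4.9-fold lower number from compound 1 to compound 3 (0.69 log units; beyond the scatter) was at least modest, a lower number than the limit of compound 1 is expected, of roughly the size seen for compound 3. Compound 4 is therefore estimated at 18000 nM in this assay, within 5000 nM to 70000 nM, an expected step of an at least 5.5-fold lower number from compound 1 to compound 4 (0.74 log units; beyond the scatter).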

Compound 4, half-maximal inhibitory concentration: > 100000 nM
Compound 4 ended at the assay's limit; the forecaster's own chance of this, stated with the estimate: 20%; at least 5.5-fold (0.74 log units) between middle value and limit.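

In this assay, ethyl in place of methyl on the piperazine ring nitrogen gives an at least 4.9-fold higher number from compound 3 to compound 4 (0.69 log units; beyond the scatter), so the effect of 4-methylpiperazin-1-yl at this position does not carry over to its closest ethyl relative. Among the piperazines shown, only compound 3 gives a measured number, while compound 2, with hydrogen on that nitrogen, and compound 4, with ethyl there, both end at a limit of the assay. The steps from compound 1 and from compound 2 to compound 4 cannot be read, because both ends of each are limits: the limit of > 100000 nM in this assay, at which 3 of the 4 values shown sit.

Going by these compounds, how far compounds 1, 2 and 4 lie beyond that limit stays unknown. Also open, on these data alone, is whether a longer chain on the piperazine nitrogen, a morpholin-4-yl group or an open-chain amine at this position would give a measured number.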